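The source may hold more compounds than are shown below. What is called first, only, known or untested is meant among the compounds shown, and "the series" means these compounds.

Among the measured compounds shown here, compound 2, with the structure `O=C(CCl)Nc1ccc(Cn2nc(-c3ccc(Oc4ccccc4)cc3)cc2CO)cc1`, is the only compound here that gives a plain number: in a functional assay on JeKo-1 cells (Homo sapiens) for inhibition, read by luminescence and CellTiter-Glo, with a stated time of 72 h (a lower number here means a stronger inhibitor, a higher number a weaker inhibitor), compound 2 gives 400 nM. Compound 1, with the structure `C/C=C/C(=O)Nc1ccc(Cn2nc(-c3ccc(Oc4ccccc4)cc3)cc2C(=O)O)cc1`, gives in this assay only > 60000 nM, which is a limit of the assay rather than a measured value. For the measured compounds named here, the one piece of evidence at hand is therefore (the limit of > 60000 nM in this assay, at which 1 of the 2 values shown sits), and compound 1 carries the same carboxy group that the new compound will bear.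

Compound 3, with the structure `O=C(CCl)Nc1ccc(Cn2nc(-c3ccc(Oc4ccccc4)cc3)cc2C(=O)O)cc1`, has not yet been measured. It differs from compound 2 in one place: carboxy in place of hydroxymethyl on an aromatic carbon. Going by the values given here, no step between two measured compounds is available to say how large such a change has been before, so the expectation rests only on the two values shown.

Because compound 1, which also holds a carboxy group, reaches only the limit > 60000 nM, a weakening beyond the usual scatter is expected. The step from compound 2 to compound 3 is estimated at a 13-fold higher number from compound 2 to compound 3 (1.10 log units; beyond the scatter). Compound 3 is expected to give about 5000 nM in this assay, somewhere between 800 nM and 60000 nM.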

Compound 3, half-maximal inhibitory concentration: 2500 nM
For compound 3 the middle estimate is 2.0-fold (0.30 log units) above the measured one, within the range that was stated.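

Among the compounds shown here, the first measured step at this position, an aromatic carbon of the five-membered ring that carries two nitrogens, shows in this assay that carboxy in place of hydroxymethyl gives a 6.3-fold higher number from compound 2 to compound 3 (0.80 log units; beyond the scatter), so the number rises beyond the scatter, yet compound 3 keeps a measurable value. Compound 1 had left open whether a carboxy-bearing compound could give a measurable value at all, and with carboxy present in both compounds, the change at the carbonyl carbon, chloromethyl in place of prop-1-en-1-yl, gives an at least 24-fold lower number from compound 1 to compound 3 (1.38 log units; beyond the scatter), which makes clear that the group on that carbonyl carbon can separate a measurable value from none. Going by these compounds, compound 1 stands at a limit of the assay rather than at a number, so this step gives only a minimum size and its true size stays unknown: the limit of > 60000 nM in this assay, at which 1 of the 3 values shown sits.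

The compounds shown hold only hydroxymethyl and carboxy at the ring position, so how a methyl ester, a primary amide or an aminomethyl group would read there remains open. Also open, on these data alone, is how hydroxymethyl would read alongside prop-1-en-1-yl on the carbonyl carbon, a pairing that would show whether the carboxy step keeps its size with that other group in place.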